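The compounds below may be only part of what the source reports. "The series", "measured", "known", "first", "only" and "open" are said of these compounds alone.

Series notes. Three compounds share one core and differ only in the group on one aromatic carbon. Compound 1 `COC(=O)/C=C/c1cccc(N(Cc2ccc(/C=C/c3scnc3C)cc2)C(=O)C(C)C)c1` carries 2-(4-methyl-1,3-thiazol-5-yl)ethenyl there and gives 228 nM in an assay on isolated protein with Bile acid receptor (Homo sapiens) as the target; on this read-out lower numbers stand for an effect already at smaller amounts and higher numbers for an effect only at larger amounts of compound. Compound 2 `CCOc1cccc(-c2ccc(CN(C(=O)C(C)C)c3cccc(/C=C/C(=O)OC)c3)cc2)c1` carries 3-ethoxyphenyl and gives 173 nM in this assay. Compound 3 `COC(=O)/C=C/c1cccc(N(Cc2ccc(-c3ccc(OC(F)(F)F)cc3)cc2)C(=O)C(C)C)c1` carries 4-(trifluoromethoxy)phenyl and gives 219 nM in this assay.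

All three numbers sit close together: a 1.3-fold lower number from compound 1 to compound 2 (0.12 log units; within the scatter), a 1.0-fold lower number from compound 1 to compound 3 (0.02 log units; within the scatter) and a 1.3-fold higher number from compound 2 to compound 3 (0.10 log units; within the scatter). Compound 3 therefore stands second highest of the three, yet within the scatter of both neighbours, so no order among them can be read.

Compound 4 `COC(=O)/C=C/c1cccc(N(Cc2ccc(-c3cccc(OC(F)(F)F)c3)cc2)C(=O)C(C)C)c1` is the next entry; it differs from compound 3 by 3-(trifluoromethoxy)phenyl in place of 4-(trifluoromethoxy)phenyl on an aromatic carbon, the same atoms joined differently. Going by the values given here, the step that bears on it most is the one from compound 2 to compound 3, where the ring substituent changed both in kind and in place and the number moved only within the scatter. The other two steps, from compound 1, were likewise flat. On this basis no step beyond the scatter is expected for compound 4 in this assay, in either direction; the expected step is a 1.0-fold higher number from compound 3 to compound 4 (0.00 log units; within the scatter). For compound 4 the estimate in this assay is 220 nM, with a range from 110 nM to 450 nM.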

Compound 4, half-maximal effective concentration: 247 nM
For compound 4 the middle estimate is 1.1-fold (0.05 log units) below the measured one; low and high end bracket the measured number.
By their numbers in this assay, from the lowest: compounds 2, 3, 1 and 4 (each within the scatter of the next).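

Moving the trifluoromethoxy group with all atoms kept is the first change in the series that tests placement alone, and in this assay it gives a 1.1-fold higher number from compound 3 to compound 4 (0.05 log units; within the scatter) and so leaves 4-(trifluoromethoxy)phenyl and 3-(trifluoromethoxy)phenyl indistinguishable. Going by these compounds alone, compound 4 also gives the first pair in which only the group on the oxygen differs, trifluoromethyl in place of ethyl with the ring placement held, and a 1.4-fold higher number from compound 2 to compound 4 (0.15 log units; within the scatter) shows that this exchange too stays within the scatter, as does the exchange for 2-(4-methyl-1,3-thiazol-5-yl)ethenyl with a 1.1-fold higher number from compound 1 to compound 4 (0.03 log units; within the scatter) as its step. No measurement at hand offers an explanation for how little these changes register at this position.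

Going by these compounds, whether any step beyond the scatter can be reached at this aromatic carbon remains open, for instance with an amine or a carboxylic acid on the phenyl ring, or with a longer chain in place of ethyl on the oxygen. On these data alone, the shared core is constant across all four compounds, so the effect of a change elsewhere on the number in this assay is also open.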